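Triazole-linked analogues tested for cytotoxicity on colon cancer cells

The compounds below may be only part of what the source reports. "The series", "measured", "known", "first", "only" and "open" are said of these compounds alone.

Compound 1 `C=C1C[C@]23C[C@@]1(O)CC[C@H]2c1ccc(O)c(C)c1[C@@H]3Cn1cc(-c2ccccn2)nn1` and compound 2 `C=C1C[C@]23C[C@@]1(O)CC[C@H]2c1ccc(O)c(C)c1[C@@H]3Cn1cc(-c2ccc(C(F)(F)F)cc2)nn1` share one core and differ only in the group on the triazole. In a functional assay on SW480 cells (Homo sapiens) for cytotoxicity, read by MTT assay, with a stated time of 4 days (on this read-out higher numbers stand for weaker inhibition and lower numbers for stronger inhibition), compound 1 gives > 20000 nM, which is a limit of the assay and not a number. In this assay compound 2 gives > 20000 nM, again a limit. The change 4-(trifluoromethyl)phenyl in place of pyridin-2-yl on an aromatic carbon therefore yields a step that the two limits leave unreadable from compound 1 to compound 2. Compound 3 `Cc1c(O)ccc2c1[C@H](Cn1cc(-c3ccccn3)nn1)[C@@]13CC(=O)[C@@](C)(CC[C@@H]21)C3` carries the pyridin-2-yl group on a different core; the difference between the two cores is not broken down here. In this assay compound 3 gives > 20000 nM, also a limit. Compound 4 `Cc1c(O)ccc2c1[C@H](Cn1cc(-c3ccc(C(F)(F)F)cc3)nn1)[C@@]13CC(=O)[C@@](C)(CC[C@@H]21)C3` is reached by the same change, (4-(trifluoromethyl)phenyl in place of pyridin-2-yl on an aromatic carbon). Since the limit of > 20000 nM in this assay, at which 3 of the 3 values shown sit, holds for every value shown, the step is expected to be a step that the limit leaves unreadable from compound 3 to compound 4, and compound 4 is estimated at 30000 nM, between 15000 nM and 80000 nM.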

Compound 4, half-maximal inhibitory concentration: > 20000 nM
Compound 4: only a limit was reported; the forecaster's own chance of this, stated with the estimate: 85%; the middle value does not contradict the limit.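

Compound 3 and compound 4 both sit at a limit and not a number, so in this assay no step can be read between them: the limit of > 20000 nM in this assay, at which 4 of the 4 values shown sit.

The compounds shown leave open whether the core or the group on the triazole changes cytotoxicity at all.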